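From (oxiran-2-yl)methyl to allyl on the shared core

This account rests on a few compounds, and the source may have more. Where it says the series, first, only, none or still open, it means among the compounds named here.

Measured in a functional assay on MCF7 cells (Homo sapiens) for cytotoxicity, read by sulforhodamine B assay, with a stated time of 48 h; on this read-out higher numbers stand for weaker inhibition and lower numbers for stronger inhibition:
- compound 1 `N#Cc1c(-c2ccc(Cl)cc2)cc(-c2ccc(Cl)cc2)n(C(=O)c2ccccc2)c1=O` gives 2.6 ug/mL
- compound 2 `N#Cc1c(-c2ccc(Cl)cc2)cc(-c2ccc(Cl)cc2)n(CC2CO2)c1=O` gives 5 ug/mL
- compound 3 `CC(=O)OC[C@H]1O[C@@H](n2c(-c3ccc(Cl)cc3)cc(-c3ccc(Cl)cc3)c(C#N)c2=O)[C@H](OC(C)=O)[C@@H](OC(C)=O)[C@@H]1OC(C)=O` gives 6.3 ug/mL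

Compound 2 holds the middle of the three numbers, but it lies within the scatter of both compound 1 and compound 3, so its place in that order carries little weight.

The next step leads to compound 4 `C=CCn1c(-c2ccc(Cl)cc2)cc(-c2ccc(Cl)cc2)c(C#N)c1=O` and reads vinyl in place of oxiran-2-yl on a saturated chain carbon bound to an aromatic nitrogen in short: vinyl in place of oxiran-2-yl on a saturated chain carbon bound to an aromatic nitrogen. Cut one bond further out, this is (oxiran-2-yl)methyl to allyl.

Within the data shown here, no measured step covers this exact change. The closest evidence is a 1.9-fold higher number from compound 1 to compound 2 (0.28 log units; within the scatter) with (oxiran-2-yl)methyl in place of benzoyl on an aromatic nitrogen, and that step stays within the scatter. Compound 3 also differs from compound 2 at this nitrogen, and its value stays within the scatter of compound 2 as well. The three compounds therefore give no sign of a large response to changes at this place, although three compounds are a thin basis.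

No step beyond the scatter, in either direction, is expected in this assay here. The estimated step is no change at the digits printed from compound 2 to compound 4 (within the scatter) and is expected to stay small. For compound 4 the estimated value is 5 ug/mL with an expected range of 2.4 ug/mL to 10.5 ug/mL for the coming measurement.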

Compound 4, half-maximal inhibitory concentration: 19 ug/mL
Estimate against measurement, compound 4: 3.8-fold (0.58 log units) below, and the stated range ends below it.
By their numbers in this assay, from the lowest: compounds 1, 2 and 3 (each within the scatter of the next, the first and the last beyond it); then compound 4.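

In this assay, the group on the aromatic nitrogen now shows a response beyond the scatter: vinyl in place of oxiran-2-yl on a saturated chain carbon bound to that nitrogen gives a 3.8-fold higher number from compound 2 to compound 4 (0.58 log units; beyond the scatter) in this series, whereas compound 1 and compound 3 each stayed within the scatter of compound 2. Allyl in place of benzoyl on the same nitrogen gives a larger step, a 7.3-fold higher number from compound 1 to compound 4 (0.86 log units; beyond the scatter), and the printed values set compound 3 at 6.3 ug/mL against compound 4 at 19 ug/mL, so compound 4 has the highest number of the four and the weakest inhibition is found with the smallest of these nitrogen groups by appearance alone, not by any measured trend. Nothing available here explains why the allyl group departs from the other three groups.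

From the compounds shown here alone, it remains open whether a plain propyl chain or a longer chain on this saturated carbon would give a number nearer compound 2 or nearer compound 4. An amine or a carboxylic acid at the end of such a chain would test whether this position tolerates a wider range of groups.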